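The compounds below may be only part of what the source reports. "The series", "measured", "known", "first", "only" and "open" are said of these compounds alone.

Notes on the series. Among the measured compounds shown here, in a functional assay on BXPC-3 cells (Homo sapiens) for antiproliferative activity, read by sulforhodamine B assay, with a stated time of 72 h (on this read-out lower numbers stand for stronger inhibition and higher numbers for weaker inhibition), compound 1 (`CC(C)(C)c1[nH]cnc1/C=c1\[nH]c(=O)/c(=C/c2cccc(C(=O)c3ccccc3)c2)[nH]c1=O`) gives 0.63 nM and compound 2 (`CC(C)(C)c1[nH]cnc1/C=c1\[nH]c(=O)/c(=C/c2cccc(C(=O)c3ccncc3)c2)[nH]c1=O`) gives 23.8 nM as the higher of the two numbers so far, beyond the scatter. Compound 3 (`CC(C)(C)c1[nH]cnc1/C=c1\[nH]c(=O)/c(=C/c2cccc(C(=O)c3ccsc3)c2)[nH]c1=O`) is not yet measured and carries thiophen-3-yl in place of pyridin-4-yl on a carbonyl carbon, counted as thiophen-3-yl in place of pyridin-4-yl on a carbonyl carbon in full. For the measured compounds named here, the one measured step bearing on this is a 38-fold higher number from compound 1 to compound 2 (1.58 log units; beyond the scatter) for pyridin-4-yl in place of phenyl on a carbonyl carbon, a large step beyond the scatter. Compound 3 gives up the pyridin-4-yl, and on the strength of a 38-fold higher number from compound 1 to compound 2 (1.58 log units; beyond the scatter) a large move toward lower numbers in this assay is expected, though no thiophen-3-yl has been measured to test this. The estimated step is a 12-fold lower number from compound 2 to compound 3 (1.08 log units; beyond the scatter) on this reading. For compound 3 the estimated value is 2 nM within an expected range of 0.5 nM to 10 nM as a working figure.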

Compound 3, half-maximal inhibitory concentration: 1.56 nM
Estimate against measurement, compound 3: 1.3-fold (0.11 log units) above; low and high end bracket the measured number.
By their numbers in this assay, from the lowest: compound 1; then compound 3; then compound 2.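

In this assay, the position on the carbonyl carbon accepts a five-membered aromatic ring: thiophen-3-yl in place of pyridin-4-yl gives a 15-fold lower number from compound 2 to compound 3 (1.18 log units; beyond the scatter), so a low number here does not depend on keeping the phenyl ring. Among the compounds shown here, the return is not complete, as thiophen-3-yl in place of phenyl still gives a 2.5-fold higher number from compound 1 to compound 3 (0.39 log units; beyond the scatter), a modest step beyond the scatter and much smaller than the one separating the pyridin-4-yl compound from the other two. Nothing available accounts for these differences.

For the compounds shown here, with only three aromatic rings at this position, the series cannot show whether the ring nitrogen of pyridin-4-yl alone sets compound 2 apart. From the compounds shown here alone, how a saturated amine such as piperidin-4-yl, a carboxylic acid on the phenyl ring or a simple alkyl chain would behave on this carbonyl carbon remains open.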